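Pendant phenyl substitution and cytotoxicity in the shared core

The source may hold more compounds than are shown below. What is called first, only, known or untested is meant among the compounds shown, and "the series" means these compounds.

Going by the values given here, compound 3 `Cc1cc(-c2ccccc2C(F)(F)F)cc(C)c1Nc1ccnc(Nc2ccc(C#N)cc2)n1` carries a 2-(trifluoromethyl)phenyl on the shared core and gives 4210 nM in an ADME assay on MT4 cells (Homo sapiens) for cytotoxicity, read by MTT assay, with a stated time of 4 days (a lower number here means that less compound is tolerated, a higher number that more compound is tolerated), the highest of the three numbers so far. Compound 2 `Cc1cc(-c2ccccc2)cc(C)c1Nc1ccnc(Nc2ccc(C#N)cc2)n1` with an unsubstituted phenyl gives 4170 nM in this assay, and the step of a 1.0-fold higher number from compound 2 to compound 3 (0.00 log units; within the scatter) is flat. Compound 1 `Cc1cc(-c2ccc(C#N)cc2)cc(C)c1Nc1ccnc(Nc2ccc(C#N)cc2)n1` with a 4-cyanophenyl gives 2080 nM; the step of a 2.0-fold higher number from compound 1 to compound 3 (0.31 log units; beyond the scatter) is the only one that reaches beyond the scatter, while a 2.0-fold higher number from compound 1 to compound 2 (0.30 log units; within the scatter) does not.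

Compound 4 `Cc1cc(-c2cccc(Cl)c2)cc(C)c1Nc1ccnc(Nc2ccc(C#N)cc2)n1` is not yet measured. The change from compound 3 is 3-chlorophenyl in place of 2-(trifluoromethyl)phenyl on an aromatic carbon. Among the compounds with values here, the steps that bear on it are the three above, which all concern the substituent on the pendant phenyl: two are within the scatter and the third is modest. Nothing in these numbers separates a chloro substituent from a trifluoromethyl or a hydrogen. The expectation for compound 4 in this assay is therefore a step of about a 1.1-fold lower number from compound 3 to compound 4 (0.04 log units; within the scatter), that is no shift beyond the scatter. The estimated value for compound 4 is 3800 nM, with a range from 1900 nM to 7600 nM.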

Compound 4, half-maximal cytotoxic concentration: 2160 nM
Beside the measured number, compound 4's estimate is 1.8-fold (0.25 log units) above it; the measured number falls inside the stated range.
By their numbers in this assay, from the lowest: compounds 1, 4, 2 and 3 (each within the scatter of the next, the first and the last beyond it).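

In this assay, a chloro group on the pendant phenyl gives no step beyond the scatter against any earlier compound: a 1.9-fold lower number from compound 2 to compound 4 (0.29 log units; within the scatter), a 1.9-fold lower number from compound 3 to compound 4 (0.29 log units; within the scatter) and a 1.0-fold higher number from compound 1 to compound 4 (0.02 log units; within the scatter). Going by these compounds alone, the series now spans four pendant groups, yet the only step beyond the scatter remains a 2.0-fold higher number from compound 1 to compound 3 (0.31 log units; beyond the scatter), and compound 4 sits within the scatter of both of those end compounds, so it adds no second clear difference at this position. No measurement is available that would account for these numbers.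

The step between 2-(trifluoromethyl)phenyl and 3-chlorophenyl changes both the substituent and its place on the pendant phenyl, so the compounds shown cannot separate those two changes. As far as these compounds go, whether an amine, a carboxylic acid or a longer chain on the pendant phenyl would give a number clearly outside the span of these four compounds in this assay also remains open.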